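A few compounds are considered here, and "the series" means these few. Any claim that something is new, unique, unknown or untested is made for them only; others in the source may bear on it.

Compound 2 `CCN1CCN(CC(=O)Nc2ccc(-c3nc(-c4ccccc4)c(-c4ccccc4)n3C)cc2)CC1` is the lower of the two measured compounds in a functional assay on MCF7 cells (Homo sapiens) for cytotoxicity, read by MTT assay, with a stated time of 24 h, tested at 1.6 ug/mL; a higher number here means a stronger effect of the compound at the concentration tested, a lower number a weaker effect: compound 2 gives 14.6%, while compound 1 `Cn1cnnc1SCC(=O)Nc1ccc(-c2nc(-c3ccccc3)c(-c3ccccc3)n2C)cc1` gives 42.8%. Among the compounds with values here, the one measured step, a number 28.2 percentage points lower from compound 1 to compound 2 (beyond the scatter), swaps the whole group on the chain carbon next to the carbonyl carbon, so it says little about a change made further out on that group.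

Compound 3 `Cn1c(-c2ccc(NC(=O)CN3CCN(c4ccccc4)CC3)cc2)nc(-c2ccccc2)c1-c1ccccc1` differs from compound 2 in one place: phenyl in place of ethyl on an amine nitrogen in a ring. The ring system and the amide link are kept; only the group on the ring nitrogen changes. Within the data shown here, no measured pair shows what this swap does, so the expectation for compound 3 rests on compound 2 alone, with wide uncertainty. The step of a number 5.4 percentage points higher from compound 2 to compound 3 (within the scatter) is therefore expected to be small and within the scatter, in either direction. Compound 3 is estimated to give 20% in this assay, in the range 5% to 45%.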

Compound 3, a percentage reported as activity, at one concentration (the size of the read-out at that concentration, not a potency): 21.3%
Compound 3: middle estimate off by 1.3 percentage points, on the low side; measured number inside the range.
By their numbers in this assay, from the lowest: compounds 2 and 3 (each within the scatter of the next); then compound 1.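

In this assay, phenyl in place of ethyl on an amine nitrogen in a ring gives a number 6.7 percentage points higher from compound 2 to compound 3 (within the scatter) and so leaves the read-out within the scatter, although the entering group has six heavy atoms and a ring while the leaving group has two heavy atoms and no ring. The gap to the triazole-bearing compound also holds with this second piperazine group, at a number 21.5 percentage points lower from compound 1 to compound 3 (beyond the scatter) for the exchange of the whole group on the chain carbon. No supporting data are available to explain either result.

The compounds shown leave open what a benzyl group, an acetyl group or a bare hydrogen on that ring nitrogen would give. They also leave open whether a phenyl ring carrying an amine or a carboxylic acid would read differently from plain phenyl.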